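The compounds below may be only part of what the source reports. "The series", "measured", "known", "first", "only" and "open" are said of these compounds alone.

Of the compounds shown here, three sharing one core have been measured in a functional assay (Oryctolagus cuniculus) for inhibition of platelet-activating factor receptor (Cavia porcellus); a higher number here means a weaker inhibitor, a lower number a stronger inhibitor. Compound 1 `CCCCCC(=O)OCC1CN(C(=O)c2cc(OC)c(OC)c(OC)c2)CCN1C(=O)c1cc(OC)c(OC)c(OC)c1` gives 290 nM. Compound 2 `CCCCNC(=O)OCC1CN(C(=O)c2cc(OC)c(OC)c(OC)c2)CCN1C(=O)c1cc(OC)c(OC)c(OC)c1` gives 240 nM. Compound 3 `CCCCCCCCNC(=O)OCC1CN(C(=O)c2cc(OC)c(OC)c(OC)c2)CCN1C(=O)c1cc(OC)c(OC)c(OC)c1` gives 370 nM. Compound 3 thus shows the highest number of the three, but the step of a 1.3-fold higher number from compound 1 to compound 3 (0.11 log units; within the scatter) and the step of a 1.5-fold higher number from compound 2 to compound 3 (0.19 log units; within the scatter) both fall inside the usual scatter, so the three compounds cannot be told apart on these numbers. The same holds for the step of a 1.2-fold lower number from compound 1 to compound 2 (0.08 log units; within the scatter).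

Compound 4 `CCCCN(CCCC)C(=O)OCC1CN(C(=O)c2cc(OC)c(OC)c(OC)c2)CCN1C(=O)c1cc(OC)c(OC)c(OC)c1` is not yet measured. It differs from compound 3 in one place: dibutylamino in place of octylamino on a carbonyl carbon. The two have the same atoms, joined differently, with the carbon chain that hung from the amide-type nitrogen now split into two shorter chains on that nitrogen.

Every earlier change at this carbonyl carbon, whether the chain was lengthened, shortened or its attachment altered, left the number within the scatter. On that basis no step beyond the scatter is expected from compound 3 to compound 4, and the estimate for compound 4 in this assay is 350 nM, with a range from 150 nM to 800 nM, meaning an expected step of a 1.1-fold lower number from compound 3 to compound 4 (0.02 log units; within the scatter).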

Compound 4, half-maximal inhibitory concentration: 1250 nM
Compound 4: middle estimate off by 3.6-fold (0.55 log units), on the low side, and the stated range ends below it.
By their numbers in this assay, from the lowest: compounds 2, 1 and 3 (each within the scatter of the next); then compound 4.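

Among the compounds shown here, at this carbonyl carbon the number had stayed within the scatter across the earlier compounds, but this assay now shows that the position is sensitive to how the chain is attached, giving a 3.4-fold higher number from compound 3 to compound 4 (0.53 log units; beyond the scatter) for the same atoms joined differently. Octylamino carries one hydrogen-bond donor and dibutylamino carries none, so the step marks the first compound here with two chains on that nitrogen and without the amide hydrogen. Compound 4 also stands apart from the other two compounds, with a 5.2-fold higher number from compound 2 to compound 4 (0.72 log units; beyond the scatter) when butyl replaces that hydrogen and a 4.3-fold higher number from compound 1 to compound 4 (0.63 log units; beyond the scatter) when dibutylamino replaces pentyl, and nothing available here accounts for these steps.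

The compounds shown leave the loss of the amide hydrogen and the splitting of the chain tied together, since both occur in compound 4, and a methyl group on the nitrogen of the octylamino compound would be one way to pull them apart. Also open, going by these compounds, is how a smaller pair of chains, as in dimethylamino, or a ring, as in piperidine, would read at this carbonyl carbon.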